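Chain variation around the thian-4-yl amine of compound 3

A few compounds are considered here, and "the series" means these few. Any claim that something is new, unique, unknown or untested is made for them only; others in the source may bear on it.

Compound 3 `c1ccc2c(c1)CN[C@@H](CN(CCCCNC1CCSCC1)[C@H]1CCCc3cccnc31)C2` is the weakest of the three measured analogues on the numbers, though only just: in a functional assay on cells for antagonist activity at C-X-C chemokine receptor type 4 (Homo sapiens), read by fluorescence and calcium flux, with stated times of 25 min and 90 s (on this read-out higher numbers stand for weaker inhibition and lower numbers for stronger inhibition), compound 3 gives 54.7 nM, while compound 1 `c1ccc2c(c1)CN[C@@H](CN(CCCCNCC1CCOCC1)[C@H]1CCCc3cccnc31)C2` gives 52.9 nM and compound 2 `O=S1(=O)CCC(CNCCCCN(C[C@H]2Cc3ccccc3CN2)[C@H]2CCCc3cccnc32)CC1` gives 17 nM. The gap a 1.0-fold higher number from compound 1 to compound 3 (0.01 log units; within the scatter) shows compounds 1 and 3 as indistinguishable, whereas a 3.2-fold higher number from compound 2 to compound 3 (0.51 log units; beyond the scatter) and a 3.1-fold lower number from compound 1 to compound 2 (0.49 log units; beyond the scatter) each lie beyond the scatter.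

Compound 4 `CC(C)(CCN(C[C@H]1Cc2ccccc2CN1)[C@H]1CCCc2cccnc21)CNCC1CCOCC1` differs from compound 3 by a group of 12 heavy atoms (10 carbon, 1 nitrogen, 1 oxygen; one six-membered non-aromatic ring with 1 hetero atom) in place of a group of 9 heavy atoms (7 carbon, 1 nitrogen, 1 sulfur; one six-membered non-aromatic ring with 1 hetero atom), on a saturated chain carbon, two bonds along the chain from an amine nitrogen. The entering group contains the oxan-4-yl motif already present in compound 1, and the step of a 1.0-fold higher number from compound 1 to compound 3 (0.01 log units; within the scatter) indicates that exchanging thian-4-yl for (oxan-4-yl)methyl on the amine nitrogen leaves the read-out unchanged. Among the measured compounds shown here, the remaining part of the change, the extra carbons on the saturated chain, has no measured counterpart in this set, so nothing supports a shift in either direction. The expectation for compound 4 is therefore a number close to compound 3, with a step of a 1.1-fold lower number from compound 3 to compound 4 (0.04 log units; within the scatter) that is not expected to exceed the scatter. Compound 4 is estimated at 50 nM in this assay, within a range from 18 nM to 140 nM.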

Compound 4, half-maximal inhibitory concentration: 43.8 nM
Beside the measured number, compound 4's estimate is 1.1-fold (0.06 log units) above it; low and high end bracket the measured number.
By their numbers in this assay, from the lowest: compound 2; then compounds 4, 1 and 3 (each within the scatter of the next).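

In this assay, placing the group of 12 heavy atoms with one ring oxygen on a saturated chain carbon, two bonds along the chain from an amine nitrogen, gives a 1.2-fold lower number from compound 3 to compound 4 (0.10 log units; within the scatter) and a 1.2-fold lower number from compound 1 to compound 4 (0.08 log units; within the scatter), so compounds 1, 3 and 4 now stand together as a cluster that this read-out does not separate. Compound 2 remains apart from that cluster, with a 2.6-fold higher number from compound 2 to compound 4 (0.41 log units; beyond the scatter), so among the four compounds only the 1,1-dioxothian-4-yl group, which carries the sulfur and two oxygens, gives a number beyond the scatter of the others. No measurement at hand accounts for either the cluster or the separate position of compound 2.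

As far as these compounds go, the step to compound 4 alters the saturated chain and the ring-bearing group together, so the contribution of each part cannot be told apart from these compounds, and whether the 1,1-dioxothian-4-yl group would keep its step on the chain of compound 4 stays open. From the compounds shown here alone, how a piperidin-4-yl ring, with a ring nitrogen in place of the sulfur or oxygen, or a carboxylic acid on the ring would read also stays open.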